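Amide side-chain isomer in the dopamine transporter series

This account rests on a few compounds, and the source may have more. Where it says the series, first, only, none or still open, it means among the compounds named here.

Measured compounds:
compound 1 `CCOC(=O)Nc1cccc2c1CN(C)CC2c1ccccc1`: 2.5 mg/kg
compound 2 `CC(C)NCC(=O)Nc1cccc2c1CN(C)CC2c1ccccc1`: about 30 mg/kg

In a functional assay on the whole organism for inhibition of sodium-dependent dopamine transporter (Mus musculus) (a lower number here means that less compound is needed, a higher number that more compound is needed for the effect), compound 1 gives 2.5 mg/kg. Going by the values given here, compound 2 gives about 30 mg/kg in this assay, the highest of the two numbers; the only other compound is compound 1, and the step of a 12-fold higher number from compound 1 to compound 2 (1.08 log units; beyond the scatter) separates them. Compound 3 `CCNCCC(=O)Nc1cccc2c1CN(C)CC2c1ccccc1` is not yet measured. It differs from compound 2 in one place: (ethylamino)methyl in place of isopropylamino on a saturated chain carbon bound to a carbonyl carbon. Among the compounds with values here, the single measured step, a 12-fold higher number from compound 1 to compound 2 (1.08 log units; beyond the scatter), exchanged the whole group on the carbonyl carbon and therefore bears on this change only loosely; the step from compound 2 to compound 3 rearranges the same atoms within the chain on the carbonyl carbon, and no measured pair shows such a rearrangement. A change within the scatter is therefore expected, no change at the digits printed from compound 2 to compound 3 (within the scatter). Compound 3 is estimated at 30 mg/kg, with a range from 10 mg/kg to 90 mg/kg.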

Compound 3, dose for half-maximal effect: 190 mg/kg
Compound 3: the middle estimate sits 6.3-fold (0.80 log units) below what was measured, and the stated range ends below it.
By their numbers in this assay, from the lowest: compound 1; then compound 2; then compound 3.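

In this assay, the side chain on the carbonyl carbon responds to how its atoms are joined, not only to which group sits there: a 6.3-fold higher number from compound 2 to compound 3 (0.80 log units; beyond the scatter) arises with the same atoms and the same counts of donors and acceptors. Set against ethoxy on the carbonyl carbon, 2-(ethylamino)ethyl gives a 76-fold higher number from compound 1 to compound 3 (1.88 log units; beyond the scatter), a larger step than a 12-fold higher number from compound 1 to compound 2 (1.08 log units; beyond the scatter) for (isopropylamino)methyl, so the two amine side chains are not interchangeable at this position. Nothing available accounts for the difference between these two isomers.

This rearrangement alters the chain and the group on its nitrogen together, and the two contributions cannot be separated here. Going by these compounds, a (ethylamino)methyl or a 2-(isopropylamino)ethyl group on the carbonyl carbon would separate them, and whether any amine side chain can approach ethoxy remains open.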